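The source may report more compounds than this note shows. Statements on the series, on what has been measured and on what is new or still open speak of the compounds shown alone.

Measured in a functional assay on cells (Erythrocyte, Homo sapiens) for inhibition, read by spectrophotometry and hemolysis, with a stated time of 10 min; on this read-out higher numbers stand for weaker inhibition and lower numbers for stronger inhibition:

compound 1 `Cc1cccc2nc(N/N=C\c3ccccc3)sc12` gives 80.1 ug/mL
compound 2 `COc1ccc(/C=N\Nc2nc3cccc(C)c3s2)cc1` gives 72.7 ug/mL
compound 3 `Cc1cccc2nc(N/N=C\c3ccc(O)c(Br)c3)sc12` gives 52.4 ug/mL

For the measured compounds named here, compound 1 and compound 2 share one core, and the only change between them is methoxy in place of hydrogen on an aromatic carbon. That change made a step of a 1.1-fold lower number from compound 1 to compound 2 (0.04 log units; within the scatter), so the two numbers cannot be told apart. Compound 3 differs from compound 1 in more than one place; how the two cores differ is not broken down here. Its number is the lowest of the three, but its gaps to compound 2 and to compound 1 both fall within the scatter, so no order among the three compounds can be read from these values.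

Compound 4 `COc1cc(/C=N\Nc2nc3cccc(C)c3s2)cc(Br)c1O` has not yet been measured. It differs from compound 3 by methoxy in place of hydrogen on an aromatic carbon. This is the same kind of change as from compound 1 to compound 2, not the same one: in compound 2 the methoxy sits para to a large group, whereas in compound 4 it sits ortho to a hydroxy group, meta to a bromo group and meta to a large group. The earlier step is the only other instance of this change among the compounds shown. In this assay, going by the values given here, the step from compound 3 to compound 4 is expected to be small, about a 1.0-fold lower number from compound 3 to compound 4 (0.02 log units; within the scatter), because the one comparable step a 1.1-fold lower number from compound 1 to compound 2 (0.04 log units; within the scatter) stayed within the scatter. On that basis compound 4 is estimated at 50 ug/mL in this assay, most likely between 30 ug/mL and 85 ug/mL.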

Compound 4, half-maximal inhibitory concentration: 56.4 ug/mL
Beside the measured number, compound 4's estimate is 1.1-fold (0.05 log units) below it; low and high end bracket the measured number.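

In this assay, putting methoxy in place of hydrogen on an aromatic carbon of the compound 3 structure gave a 1.1-fold higher number from compound 3 to compound 4 (0.03 log units; within the scatter), a step too small to separate the two numbers. Set beside the earlier case, the same change looks alike on the two cores: the same change on two cores in this assay, a 1.1-fold lower number (0.04 log units; within the scatter) from compound 1 to compound 2 and a 1.1-fold higher number (0.03 log units; within the scatter) from compound 3 to compound 4, 1.2-fold (0.07 log units) apart, within the scatter of two such steps This shows that in both pairs the swap of hydrogen for methoxy left the read-out inside the normal spread of repeat measurements, whether the ring carried only the large group or also a hydroxy group and a bromo group, but it rests on just two pairs and does not show that the change would stay this small on any other core in the series, nor does it explain why the steps are small.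

The compounds shown leave open whether a different group on this ring, such as an amine, a carboxylic acid or a longer chain, would produce a step beyond the scatter. For the compounds shown here, no compound here carries the hydroxy group without the bromo group, so what each of the two does on its own also remains unknown.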